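Methylamino to ethylamino on two ketone and alkene cores

This account rests on a few compounds, and the source may have more. Where it says the series, first, only, none or still open, it means among the compounds named here.

Measured compounds:
- compound 1, `CNCC(=O)Nc1cc(OC)ccc1C(=O)c1ccc2c(c1)C=CC(C)(C)O2`: 850 nM
- compound 2, `CCNCC(=O)Nc1cc(OC)ccc1C(=O)c1ccc2c(c1)C=CC(C)(C)O2`: 2070 nM
- compound 3, `C=C(c1ccc(OC)cc1NC(=O)CNC)c1ccc(OC)c2c1C=CC(C)(C)O2`: 720 nM

All three were run in a functional assay on A2780 cells (Homo sapiens) for antiproliferative activity, read by MTT assay, with a stated time of 48 h; a lower number here means a stronger inhibitor, a higher number a weaker inhibitor. Compound 1 gives 850 nM and compound 2 gives 2070 nM. The change between them is methyl in place of hydrogen on a saturated chain carbon bound to an amine nitrogen, and the step it made was a 2.4-fold higher number from compound 1 to compound 2 (0.39 log units; beyond the scatter).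

Compound 3 carries a different core; the difference between the core of compound 3 and that of compound 1 is not broken down here. In this assay compound 3 gives 720 nM, which stands within the scatter of compound 1 and beyond it from compound 2.

Compound 4, `C=C(c1ccc(OC)cc1NC(=O)CNCC)c1ccc(OC)c2c1C=CC(C)(C)O2`, is not yet measured. It differs from compound 3 by methyl in place of hydrogen on a saturated chain carbon bound to an amine nitrogen. The place of this change reads the same, word for word, as for the pair of compound 1 and compound 2, so it is the same change, now made on the core of compound 3. For the measured compounds named here, with only one measured instance of it, the expectation rests on that one pair: a weakening of about the size of a 2.4-fold higher number from compound 1 to compound 2 (0.39 log units; beyond the scatter) is taken as the most likely outcome on the new core as well, though a single pair gives no guarantee that the two cores respond alike.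

Compound 4 is therefore expected to give 1700 nM in this assay, estimated between 900 nM and 3600 nM, which means an expected step of a 2.4-fold higher number from compound 3 to compound 4 (0.37 log units; beyond the scatter).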

Compound 4, half-maximal inhibitory concentration: 2010 nM
Compound 4: middle estimate off by 1.2-fold (0.07 log units), on the low side; low and high end bracket the measured number.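

On the core of compound 3, the change from methylamino to ethylamino gave a 2.8-fold higher number from compound 3 to compound 4 (0.45 log units; beyond the scatter) in this assay. Set beside the step on the core of compound 1, the change carries over in direction and in size: the same change on two cores in this assay, a 2.4-fold higher number (0.39 log units; beyond the scatter) from compound 1 to compound 2 and a 2.8-fold higher number (0.45 log units; beyond the scatter) from compound 3 to compound 4, 1.1-fold (0.06 log units) apart, within the scatter of two such steps This shows that the weakening from methyl to ethyl on a saturated chain carbon bound to an amine nitrogen held on both cores shown, but it rests on only two pairs in this assay, and it does not show that any further core would respond alike or why the number rises.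

The compounds shown leave open whether a longer chain such as propyl, a branched group such as isopropyl, or a ring such as cyclopropyl on the amine nitrogen would extend the same trend on either core. They also leave open whether an unsubstituted amine or a dimethylamino group in place of methylamino would give steps that match between the core of compound 1 and the core of compound 3.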